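The source may report more compounds than this note shows. Statements on the series, on what has been measured and on what is new or still open speak of the compounds shown alone.

Measured in a functional assay on NCI-H157 cells (Homo sapiens) for cytotoxicity, read by resazurin assay, with a stated time of 72 h; on this read-out lower numbers stand for stronger inhibition and higher numbers for weaker inhibition:
- Compound 1 `COc1cc(/C=C/C(=O)OCCCO[N+](=O)[O-])ccc1OCCCO[N+](=O)[O-]`: > 50000 nM
- Compound 2 `COc1cc(/C=C/C(=O)OCc2c(-c3ccccc3)no[n+]2[O-])ccc1O`: 4530 nM

Compound 1 gives > 50000 nM, which is a limit of the assay and not a number. This is the limit of > 50000 nM in this assay, at which 1 of the 2 values shown sits. Its true place on the scale is therefore unknown.

Compound 3 `COc1cc(/C=C/C(=O)OCCCO[N+](=O)[O-])ccc1O` differs from compound 1 by one change: hydrogen in place of 3-(nitrooxy)propyl on an oxygen on an aromatic ring. A 3-(nitrooxy)propoxy group becomes a hydroxy group, and the rest of the structure stays the same.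

Going by the values given here, no measured pair shows this change, so any forecast is uncertain. Among the compounds with values here, the only exact reading is that of compound 2, at 4530 nM. A modest shift towards stronger inhibition in this assay is expected, leaving compound 3 weaker than that reading and possibly still at the limit. The expected size is an at least 1.4-fold lower number from compound 1 to compound 3 (0.15 log units; that floor lies within the scatter). For compound 3 the estimated value is 35000 nM, with an expected range from 12000 nM to 80000 nM.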

Compound 3, half-maximal inhibitory concentration: 20500 nM
Estimate against measurement, compound 3: 1.7-fold (0.23 log units) above; low and high end bracket the measured number.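

In this assay, going by these compounds alone, putting hydrogen in place of 3-(nitrooxy)propyl on the oxygen on the aromatic ring gives the first step that can be read for this position: an at least 2.4-fold lower number from compound 1 to compound 3 (0.38 log units; beyond the scatter). Compound 1 gives > 50000 nM, which is a limit of the assay and not a number. The step is therefore only a floor, and the full size of this change stays unknown: the limit of > 50000 nM in this assay, at which 1 of the 3 values shown sits.

The compounds shown leave open whether the shift comes from losing the 3-(nitrooxy)propyl chain or from gaining the free hydroxy group, and a methyl group or a shorter chain on this oxygen would help separate the two. Also open, as far as these compounds go, is what the remaining 3-(nitrooxy)propyl chain adds to compound 3, which a carboxylic acid in place of its ester could address.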